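A few compounds are considered here, and "the series" means these few. Any claim that something is new, unique, unknown or untested is made for them only; others in the source may bear on it.

Measured compounds:

Compound 1, `CC(C)C[C@H](NC(=S)NCc1ccccc1)c1nc2ccccc2[nH]1`, in a functional assay on A549 cells (Homo sapiens) for cytotoxicity, read by MTT assay (on this read-out lower numbers stand for stronger inhibition and higher numbers for weaker inhibition), gives 75700 nM.
Compound 2, `CC(C)C[C@H](NC(=S)Nc1ccccc1)c1nc2ccccc2[nH]1`, in this assay gives 28600 nM.
Compound 3, `C[C@@H](NC(=S)NCc1ccccc1)c1nc2ccccc2[nH]1`, in this assay gives 18700 nM.

These three compounds share a thiourea linking a benzimidazole-bearing side to either a benzyl or a phenyl group. Compound 1 and compound 2 differ in one place: phenyl in place of benzyl on an amide-type nitrogen. That single change brought a 2.6-fold lower number from compound 1 to compound 2 (0.42 log units; beyond the scatter), a step beyond the usual scatter, so it is read as a real shift toward stronger inhibition. Compound 3 carries the benzyl group of compound 1 but a different core; the difference between the two cores is not broken down here. Compound 3 and compound 2 lie within the scatter of each other, so no order between them can be read.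

Compound 4, `C[C@@H](NC(=S)Nc1ccccc1)c1nc2ccccc2[nH]1`, has not yet been measured in this assay. It stands to compound 3 as compound 2 stands to compound 1: phenyl in place of benzyl on an amide-type nitrogen. Going by the values given here, since the one measured example of this change is the step from compound 1 to compound 2, the expectation is that the same change on the core of compound 3 moves the number in the same direction and by a similar amount, giving an expected step of a 2.3-fold lower number from compound 3 to compound 4 (0.37 log units; beyond the scatter). This rests on a single pair, so the range is kept wide. Compound 4 is therefore estimated at 8000 nM in this assay, expected to fall between 3000 nM and 20000 nM.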

Compound 4, half-maximal inhibitory concentration: 14800 nM
Beside the measured number, compound 4's estimate is 1.9-fold (0.27 log units) below it; measured number inside the range.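

In this assay, phenyl in place of benzyl on the amide-type nitrogen of the second core brings a 1.3-fold lower number from compound 3 to compound 4 (0.10 log units; within the scatter), so no order of the two compounds can be read. Set beside the earlier case, the two steps are no further apart than repeated measurements could make them: the same change on two cores in this assay, a 2.6-fold lower number (0.42 log units; beyond the scatter) from compound 1 to compound 2 and a 1.3-fold lower number (0.10 log units; within the scatter) from compound 3 to compound 4, 2.1-fold (0.32 log units) apart, within the scatter of two such steps. This fits the idea that the change carries over from one core to the other, but it does not prove it, since one step is a real shift and the other cannot be told from no shift at all, and two pairs can neither establish a shared effect nor show that the core alters it.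

The compounds shown leave open what other groups on this nitrogen would do, such as a longer chain like phenylethyl, a small methyl, or a phenyl ring carrying an amine or a carboxylic acid. They also leave open whether the swap from benzyl to phenyl would give a clear shift or none on further cores, which only more matched pairs could settle.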